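The source may report more compounds than this note shows. Statements on the series, on what has been measured and on what is new or still open speak of the compounds shown alone.

Compound 1 `Cc1nn2c(-c3nc4cc(Cl)c(Cl)cc4[nH]3)c(-c3ccccc3)nc2s1` gives 19100 nM
Compound 2 `Cc1nn2c(-c3nc4ccccc4[nH]3)c(-c3ccccc3)nc2s1` gives > 30000 nM (a limit of the assay, not a number)
Compound 3 `Cc1ccc2[nH]c(-c3c(-c4ccc(F)cc4)nc4sc(C)nn34)nc2c1` gives 19900 nM

In a functional assay on DU-145 cells (Homo sapiens) for antiproliferative activity, read by MTT assay (a lower number here means a stronger inhibitor, a higher number a weaker inhibitor), compound 3 gives 19900 nM and stands within the usual scatter of compound 1, which gives 19100 nM in the same test. The next compound, compound 4 `Cc1nn2c(-c3nc4ccccc4[nH]3)c(-c3ccc(F)cc3)nc2s1`, differs from compound 3 by one small change, hydrogen in place of methyl on an aromatic carbon that is, hydrogen in place of methyl on an aromatic carbon. Within the data shown here, no measured pair shows this change alone, so its size cannot be read directly. Compound 2 also has no methyl at that place, and it gives > 30000 nM as a limit of the assay. On that basis, a small move toward a higher number is expected in this assay and may not exceed the scatter. The estimate amounts to an expected step of a 1.3-fold higher number from compound 3 to compound 4 (0.12 log units; within the scatter) in this test. For compound 4 the estimated value is 26000 nM with an expected range from 14000 nM to 40000 nM in this test.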

Compound 4, half-maximal inhibitory concentration: > 30000 nM
Compound 4: only a limit was reported; the forecaster's own chance of this, stated with the estimate: 50%; at least 1.1-fold (0.06 log units) between middle value and limit.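

Hydrogen in place of methyl on an aromatic carbon can now be seen alone, in a pair of compounds that differ only in this one place, and this assay gives an at least 1.5-fold higher number from compound 3 to compound 4 (0.17 log units; that floor lies within the scatter). Compound 4 is reported only as a limit of the assay, which leaves the true size of this step unknown, and the part that can be read does not clear the usual scatter. The step between compound 2 and compound 4, fluoro in place of hydrogen on an aromatic carbon, cannot be read: the limit of > 30000 nM in this assay, at which 2 of the 4 values shown sit.

The compounds shown leave open how a methoxy group or an amine on that same aromatic carbon would behave in this assay. They also leave open what fluoro does when both compounds of a pair give a real number.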